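Pyridin-2-yl in place of 3-methylphenyl: expected response

This account rests on a few compounds, and the source may have more. Where it says the series, first, only, none or still open, it means among the compounds named here.

Measured so far:
compound 1 `Cc1ccccc1-c1ccccc1OC(C)C1=NCCN1` — in a functional assay on CHO cells for agonist activity at Alpha-2B adrenergic receptor (Homo sapiens) (a lower number here means a smaller maximal response, a higher number a larger maximal response), compound 1 gives < 0.3, a limit of the assay.
compound 2 `Cc1cccc(-c2ccccc2OC(C)C2=NCCN2)c1` — in this assay compound 2 gives < 0.3, also a limit of the assay.

Compound 2 thus stands only at a limit in this assay; no number is known for it. Within the data shown here, the one measured step, a step that the two limits leave unreadable from compound 1 to compound 2, cannot be read because the limit of < 0.3 in this assay, at which 2 of the 2 values shown sit, hides its size and direction.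

Compound 3 `CC(Oc1ccccc1-c1ccccn1)C1=NCCN1` is not yet measured. It differs from compound 2 by pyridin-2-yl in place of 3-methylphenyl on an aromatic carbon.

Among the measured compounds shown here, no measured step bears on this change. For the measured compounds named here, the only guide is that both compounds sharing the core sit at the limit, so compound 3 is expected to stay low in this assay, with a step that the limit leaves unreadable from compound 2 to compound 3 as the expected step. Compound 3 is estimated at 0.2, between 0.05 and 0.45.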

Compound 3, intrinsic activity: the largest response reached, as a fraction of the reference agonist's: < 0.3
Compound 3 gave a limit, no number (the forecaster's own chance of this, stated with the estimate: 65%); the middle value is on the limit's open side.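

Among these compounds, compound 1, compound 2 and compound 3 all sit at a limit, so no step among them can be read: the limit of < 0.3 in this assay, at which 3 of the 3 values shown sit. The compounds shown leave open how 2-methylphenyl, 3-methylphenyl and pyridin-2-yl compare in this assay, as none of the three has a number.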